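Catechol to benzyl ether at the diaryl ether oxygen

The source may report more compounds than this note shows. Statements on the series, on what has been measured and on what is new or still open speak of the compounds shown alone.

Measured compounds:
compound 1 `O=C(NCCNS(=O)(=O)c1ccc(-c2ccccc2Oc2ccc(O)c(O)c2)s1)Nc1cc(Cl)cc(Cl)c1`: 4500 nM
compound 2 `O=C(NCCNS(=O)(=O)c1cc(-c2ccccc2Oc2ccc(O)c(O)c2)cs1)Nc1cc(C(F)(F)F)cc(C(F)(F)F)c1`: 3900 nM
compound 3 `O=[N+]([O-])c1ccc(NC(=S)N2CCN(S(=O)(=O)c3sccc3-c3ccccc3Oc3ccc(O)c(O)c3)CC2)cc1`: 9000 nM

In a functional assay on RS4-11 cells (Homo sapiens) for inhibition, read by CCK-8 assay, with a stated time of 48 h (a lower number here means a stronger inhibitor, a higher number a weaker inhibitor), compound 1 gives 4500 nM. Its number sits between those of compound 2 and compound 3, and all three fall within the usual scatter of one another, so no ranking among them can be drawn.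

Compound 4 `O=C(NCCNS(=O)(=O)c1ccc(-c2ccccc2OCc2ccccc2)s1)Nc1cc(Cl)cc(Cl)c1` has not been measured. Relative to compound 1 the change is benzyl in place of 3,4-dihydroxyphenyl on an oxygen on an aromatic ring. Two hydrogen-bond donors and two acceptors are lost with the 3,4-dihydroxyphenyl group, and nothing comparable enters.

Going by the values given here, no measured pair shows this change, so the size of the step is uncertain. A modest move toward a higher number is expected, a 1.8-fold higher number from compound 1 to compound 4 (0.25 log units; within the scatter), giving an estimate for compound 4 of 8000 nM with a range from 2500 nM to 25000 nM.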

Compound 4, half-maximal inhibitory concentration: > 20000 nM
Compound 4 was reported as a limit; the forecaster's own chance of this, stated with the estimate: 20%; middle value at least 2.5-fold (0.39 log units) away from the limit.
By their numbers in this assay, from the lowest: compounds 2, 1 and 3 (each within the scatter of the next, the first and the last beyond it). At a limit, above all of these: compound 4.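

In this assay, going by these compounds alone, benzyl in place of 3,4-dihydroxyphenyl on this oxygen gives an at least 4.4-fold higher number from compound 1 to compound 4 (0.64 log units; beyond the scatter), so unlike the differences among the earlier compounds, this change reaches beyond the scatter. Compound 4 gives > 20000 nM, which is a limit of the assay and not a number. The full size of the step cannot be read, because the value is only a limit: the limit of > 20000 nM in this assay, at which 1 of the 4 values shown sits.

The compounds shown leave open whether the loss follows from removing the hydroxyl groups or from adding the benzyl carbon. A dihydroxybenzyl or dimethoxyphenyl group on the same oxygen would help separate the two.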